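Sulfamoyl chain variants of an indoleamine dioxygenase inhibitor series

The compounds below may be only part of what the source reports. "The series", "measured", "known", "first", "only" and "open" are said of these compounds alone.

Measured compounds:
compound 1 `NNc1nonc1/C(=N/O)Nc1ccc(F)c(Br)c1`: 556 nM
compound 2 `[O-][S+]1CC(Nc2nonc2/C(=N/O)Nc2ccc(F)c(Br)c2)C1`: 79 nM
compound 3 `NS(=O)(=O)CCNc1nonc1/C(=N/O)Nc1ccc(F)c(Br)c1`: 11 nM

In an assay on HeLa cells for inhibition of Indoleamine 2,3-dioxygenase 1 (Homo sapiens), read by spectrophotometry, with a stated time of 24 h (on this read-out higher numbers stand for an effect only at larger amounts of compound and lower numbers for an effect already at smaller amounts), compound 1 gives 556 nM, the highest of the three numbers. The nearest is compound 2, reached by a 7.0-fold lower number from compound 1 to compound 2 (0.85 log units; beyond the scatter); the furthest is compound 3, reached by a 51-fold lower number from compound 1 to compound 3 (1.70 log units; beyond the scatter). Between the two substituted compounds the step is a 7.2-fold lower number from compound 2 to compound 3 (0.86 log units; beyond the scatter).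

The untested compound 4 `CCNS(=O)(=O)CCNc1nonc1/C(=N/O)Nc1ccc(F)c(Br)c1` differs from compound 1 by 2-(ethylsulfamoyl)ethyl in place of amino on a nitrogen on an aromatic ring. Among the measured compounds shown here, the step that bears most directly on it is the one to compound 3, a large drop, since compound 4 carries the same 2-sulfamoylethyl chain extended by an ethyl on its sulfamoyl nitrogen. The step to compound 2 shows that a different replacement of the amino group also lowers the number, though modestly. For the measured compounds named here, there is no measured pair showing what the added ethyl alone does.

Compound 4 is therefore expected to give a number well below that of compound 1, with a 37-fold lower number from compound 1 to compound 4 (1.57 log units; beyond the scatter) anticipated to be close to the large step seen for compound 3. The estimate for compound 4 is 15 nM, within a range from 5 nM to 50 nM.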

Compound 4, half-maximal effective concentration: 41 nM
Estimate against measurement, compound 4: 2.7-fold (0.44 log units) below, and the stated range covers the measured number.
By their numbers in this assay, from the lowest: compound 3; then compounds 4 and 2 (each within the scatter of the next); then compound 1.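

In this assay, among the compounds shown here, the sulfonamide nitrogen proves sensitive to substitution, which no earlier pair could show: placing ethyl on it in place of hydrogen raises the number (a 3.7-fold higher number from compound 3 to compound 4 (0.57 log units; beyond the scatter)). The large drop from the amino group nevertheless survives this change, since the 2-(ethylsulfamoyl)ethyl chain still gives a much lower number than amino (a 14-fold lower number from compound 1 to compound 4 (1.13 log units; beyond the scatter)). The clear separation of the unsubstituted chain from the four-membered ring does not carry over to the ethyl chain, as these two substituents cannot be told apart (a 1.9-fold lower number from compound 2 to compound 4 (0.28 log units; within the scatter)).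

No evidence is available that explains the effect of the ethyl group. Going by these compounds, it remains open whether a methyl on the sulfonamide nitrogen, a 3-sulfamoylpropyl chain or a carboxylic acid in place of the sulfamoyl group would give a number closer to that of compound 3 or to that of compound 4.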